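The compounds below may be only part of what the source reports. "The series", "measured", "known", "first", "only" and "open" are said of these compounds alone.

Measured in a functional assay on ECa-109 cells for inhibition, with ECa-109 cell line (Homo sapiens) as the target, read by MTT assay, with a stated time of 48 h; a lower number here means a stronger inhibitor, a higher number a weaker inhibitor:
- Compound 1 `COc1ccc(-c2coc3cc(OCCCCSC(=S)N4CCN(C(=O)OC(C)(C)C)CC4)ccc3c2=O)cc1`: 8840 nM
- Compound 2 `CCN1CCN(C(=S)SCCCOc2ccc3c(=O)c(-c4ccc(OC)cc4)coc3c2)CC1`: 36900 nM
- Compound 3 `COc1ccc(-c2coc3cc(OCCCSC(=S)N4CCN(C(C)=O)CC4)ccc3c2=O)cc1`: 24700 nM

Compound 2 stands level, within the scatter, with compound 3, while compound 1 shows a clearly lower number than either of them. The next compound, compound 4 `COc1ccc(-c2coc3cc(OCCCSC(=S)N4CCN(C(=O)OC(C)(C)C)CC4)ccc3c2=O)cc1`, has tert-butoxycarbonyl in place of ethyl on an amine nitrogen in a ring. For the measured compounds named here, one measured step bears directly on this nitrogen. That step, a 1.5-fold lower number from compound 2 to compound 3 (0.17 log units; within the scatter), replaces the same ethyl with acetyl and stays within the scatter. The linking chain of compound 4 differs from that of compound 1, which bears tert-butoxycarbonyl at this nitrogen too, so compound 1 with its 8840 nM is only a partial guide. Taken together, these results point to a modest move toward a lower number in this assay, near the edge of the scatter. The expected step is a 1.9-fold lower number from compound 2 to compound 4 (0.29 log units; within the scatter). The estimated value for compound 4 is 19000 nM, with an expected range from 8500 nM to 38000 nM.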

Compound 4, half-maximal inhibitory concentration: 3540 nM
The estimate for compound 4 lay 5.4-fold (0.73 log units) above the measured number, outside the stated range (below it).
By their numbers in this assay, from the lowest: compound 4; then compound 1; then compounds 3 and 2 (each within the scatter of the next).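

In this assay the amine nitrogen in the ring now proves sensitive to what it carries, with tert-butoxycarbonyl in place of ethyl giving a 10-fold lower number from compound 2 to compound 4 (1.02 log units; beyond the scatter) and going beyond the scatter, which the acetyl step alone, a 1.5-fold lower number from compound 2 to compound 3 (0.17 log units; within the scatter), had not shown. A carbonyl on this nitrogen is thus not enough by itself, since compound 3 has one too, and the exchange of its methyl for tert-butoxy on that carbonyl carbon gives a 7.0-fold lower number from compound 3 to compound 4 (0.84 log units; beyond the scatter) and carries most of the move. No evidence at hand says why this exchange matters.

The compounds shown leave open whether a benzyloxycarbonyl or a pivaloyl group on this nitrogen would give a number like that of compound 4. Where the free secondary amine would fall also stays open.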